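Hydroxy in Place of Methoxy on the Phenyl Ring

A few compounds are considered here, and "the series" means these few. Any claim that something is new, unique, unknown or untested is made for them only; others in the source may bear on it.

Compound 1 `COc1cc(C)cc(-c2c(-c3ccnc(-c4ccc(N(C)C)cc4)c3)cnn2CC#N)c1` gives 127 nM in a functional assay on SF-539 cells (Homo sapiens) for inhibition, read by sulforhodamine B assay, with a stated time of 48 h; a lower number here means a stronger inhibitor of growth, a higher number a weaker inhibitor of growth.
Compound 2 `COc1cc(C)cc(-c2nn(CC#N)cc2-c2ccnc(-c3ccc(N(C)C)cc3)c2)c1` gives 259 nM in this assay.

In this assay compound 2 carries the higher of the two numbers, and its gap to compound 1 lies beyond the usual scatter. Compound 3 `Cc1cc(O)cc(-c2nn(CC#N)cc2-c2ccnc(-c3ccc(N(C)C)cc3)c2)c1` is compound 2 with one change: hydrogen in place of methyl on an oxygen on an aromatic ring. Going by the values given here, no measured pair shows this change, so its effect is unknown here. The step from compound 2 to compound 3 is expected to be small, likely within the scatter, a 1.2-fold higher number from compound 2 to compound 3 (0.06 log units; within the scatter). Compound 3 is estimated at 300 nM, with a range from 100 nM to 900 nM.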

Compound 3, concentration for 50% growth inhibition: 2120 nM
The estimate for compound 3 lay 7.1-fold (0.85 log units) below the measured number; measured number outside the range, above it.
By their numbers in this assay, from the lowest: compound 1; then compound 2; then compound 3.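

Methoxy and hydroxy differ only by a methyl on the oxygen, yet at this position on the phenyl ring that difference counts: in this assay the change gives an 8.2-fold higher number from compound 2 to compound 3 (0.91 log units; beyond the scatter) and so weakens growth inhibition clearly. Keeping the methyl on this oxygen therefore matters for compound 2. Nothing available here accounts for the size of this step.

From the compounds shown here alone, whether the same change would cost as much on compound 1 stays open. So does how a longer chain on this oxygen, such as ethoxy, or an amine in place of methoxy would read.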